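The source may report more compounds than this note shows. Statements on the series, on what has been measured and on what is new or still open speak of the compounds shown alone.

Measured compounds in a functional assay on HeLa cells (Homo sapiens) for antiproliferative activity, read by CCK-8 assay, with a stated time of 72 h; on this read-out lower numbers stand for stronger inhibition and higher numbers for weaker inhibition:

compound 1 `O=C(Nc1cccc(-c2oc3cc(-c4ccc(F)cc4)ccc3c(=O)c2O)c1)c1ccc(F)cc1` gives 5350 nM
compound 2 `O=C(Nc1cccc(-c2oc3cc(-c4ccc(F)cc4)ccc3c(=O)c2O)c1)c1ccc(Br)cc1` gives 9740 nM
compound 3 `Cc1cc(C)cc(C(=O)Nc2cccc(-c3oc4cc(-c5ccc(F)cc5)ccc4c(=O)c3O)c2)c1` gives 5540 nM

Compound 3 sits second highest of the three numbers, but all three lie within the scatter of one another: the step from compound 1 to compound 3 is a 1.0-fold higher number from compound 1 to compound 3 (0.02 log units; within the scatter), and the step from compound 2 to compound 3 is a 1.8-fold lower number from compound 2 to compound 3 (0.25 log units; within the scatter). The three compounds share a core and differ only in the aromatic group on the carbonyl carbon of the amide, and none of these exchanges moved this assay beyond its usual spread.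

Compound 4 `O=C(Nc1cccc(-c2oc3cc(-c4ccc(F)cc4)ccc3c(=O)c2O)c1)c1ccc(Cl)nc1` continues this series at the same site. The change is 6-chloropyridin-3-yl in place of 3,5-dimethylphenyl on a carbonyl carbon. Going by the values given here, the steps that bear on it are the two exchanges already seen at this carbonyl carbon, a 1.0-fold higher number from compound 1 to compound 3 (0.02 log units; within the scatter) and a 1.8-fold lower number from compound 2 to compound 3 (0.25 log units; within the scatter), together with the halogen swap a 1.8-fold higher number from compound 1 to compound 2 (0.26 log units; within the scatter); each stayed within the scatter. On that basis no step beyond the scatter is expected in this assay, and the step from compound 3 to compound 4 is estimated as a 1.1-fold higher number from compound 3 to compound 4 (0.03 log units; within the scatter). Compound 4 is therefore expected to give about 6000 nM, with a plausible range from 3000 nM to 12000 nM.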

Compound 4, half-maximal inhibitory concentration: 4080 nM
For compound 4 the middle estimate is 1.5-fold (0.17 log units) above the measured one, within the range that was stated.
By their numbers in this assay, from the lowest: compounds 4, 1, 3 and 2 (each within the scatter of the next, the first and the last beyond it).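

In this assay, going by these compounds alone, the 6-chloropyridin-3-yl group is the only group on this carbonyl carbon so far with a hetero atom in its ring and a hydrogen-bond acceptor, and this exchange leaves the read-out within the usual scatter of two of the earlier groups: a 1.4-fold lower number from compound 3 to compound 4 (0.13 log units; within the scatter), and a 1.3-fold lower number from compound 1 to compound 4 (0.12 log units; within the scatter). Against the 4-bromophenyl group, however, the same group gives the only step at this position that passes the scatter, a 2.4-fold lower number from compound 2 to compound 4 (0.38 log units; beyond the scatter), so the position is not wholly indifferent to what sits there, although the step is modest and the other two steps do not pass the scatter. Nothing among the available data accounts for this difference.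

The 6-chloropyridin-3-yl group differs from the aromatic groups before it in both its ring nitrogen and its chlorine, so the compounds shown cannot assign the step to either one, and a pyridin-3-yl or a 4-chlorophenyl group would be needed to separate them. They also leave open whether a saturated ring such as cyclohexyl, or an amine such as morpholine, would be accepted on this carbonyl carbon.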